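Methoxy on the aromatic ring of compound 1

A few compounds are considered here, and "the series" means these few. Any claim that something is new, unique, unknown or untested is made for them only; others in the source may bear on it.

Measured so far in a functional assay on HCT-116 cells (Homo sapiens) for antiproliferative activity, read by MTT assay, with a stated time of 72 h (on this read-out lower numbers stand for stronger inhibition and higher numbers for weaker inhibition), are three compounds:
Compound 1 `O=C(CCc1cccc2c1B(O)OC2)Nc1ccccc1` gives 350 nM
Compound 2 `CC(C)(C)c1ccc(NC(=O)CCc2cccc3c2B(O)OC3)cc1` gives 19000 nM
Compound 3 `CC(C)c1cccc(NC(=O)CCc2cccc3c2B(O)OC3)c1` gives 1600 nM

Compound 1 has the lowest number of the three, and its gaps to compound 2 and compound 3 both lie beyond the scatter. Compound 4 `COc1ccccc1NC(=O)CCc1cccc2c1B(O)OC2` is the next to be read in this assay and departs from compound 1 by one change. That change is methoxy in place of hydrogen on an aromatic carbon and it amounts to methoxy in place of hydrogen on an aromatic carbon, ortho to a large group.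

Within the data shown here, two measured steps bear on it. Tert-butyl in place of hydrogen on an aromatic carbon gave a 54-fold higher number from compound 1 to compound 2 (1.73 log units; beyond the scatter) and counts as large. Isopropyl in place of hydrogen on an aromatic carbon gave a 4.6-fold higher number from compound 1 to compound 3 (0.66 log units; beyond the scatter) and counts as modest. Both steps lead to weaker inhibition, and neither of the two compounds goes against that. Neither step, however, involves a methoxy, so they offer only a loose guide. A modest loss seems the likeliest outcome, though a large one cannot be ruled out. The expected step is a 2.3-fold higher number from compound 1 to compound 4 (0.36 log units; beyond the scatter) and would mean weaker inhibition. Compound 4 is estimated at 800 nM with an expected range from 250 nM to 3000 nM in this reading.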

Compound 4, half-maximal inhibitory concentration: 430 nM
Beside the measured number, compound 4's estimate is 1.9-fold (0.27 log units) above it, within the range that was stated.
By their numbers in this assay, from the lowest: compounds 1 and 4 (each within the scatter of the next); then compound 3; then compound 2.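

In this assay methoxy in place of hydrogen on an aromatic carbon, ortho to a large group, gives a 1.2-fold higher number from compound 1 to compound 4 (0.09 log units; within the scatter) and so leaves the number where it was, as far as the scatter allows. The tert-butyl and isopropyl steps, a 54-fold higher number from compound 1 to compound 2 (1.73 log units; beyond the scatter) and a 4.6-fold higher number from compound 1 to compound 3 (0.66 log units; beyond the scatter), had shown only weaker inhibition, whereas compound 4 shows that this aromatic ring of compound 1 can carry an added group without a loss that stands beyond the scatter. No measurement at hand accounts for this difference between the methoxy and the two alkyl groups.

Compounds 2, 3 and 4 differ from one another in both the group and its place on the ring, so the compounds shown cannot tell whether the result belongs to the methoxy or to its place. From the compounds shown here alone, it also remains open how methoxy would read at the other places on this ring, and how a hydroxyl, an amine or a carboxylic acid would read at the place methoxy occupies in compound 4.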